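The source may report more compounds than this note shows. Statements on the series, on what has been measured and on what is new or still open speak of the compounds shown alone.

Measured so far:
compound 1 `CC[C@H]1CN(c2ncc(C#N)cc2Cl)CCN1C1CCN(Cc2ccc(Cl)cc2F)CC1` — 50.5 nM in an assay on isolated protein for binding affinity to C-X-C chemokine receptor type 3 (Homo sapiens); a lower number here means a stronger inhibitor, a higher number a weaker inhibitor
compound 2 `CC[C@H]1CN(c2ncc(-c3nnc[nH]3)cc2Cl)CCN1C1CCN(Cc2ccc(Cl)cc2F)CC1` — 6.8 nM
compound 3 `CC[C@H]1CN(c2ncc(-c3nnn[nH]3)cc2Cl)CCN1C1CCN(Cc2ccc(Cl)cc2F)CC1` — 1380 nM

Compound 2 gives the lowest number of the three in this assay; its nearest neighbour is compound 1, with a step of a 7.4-fold lower number from compound 1 to compound 2 (0.87 log units; beyond the scatter), and its furthest is compound 3, with a step of a 200-fold higher number from compound 2 to compound 3 (2.31 log units; beyond the scatter). The variation in this set sits entirely on the same aromatic carbon of the shared core, and all three changes there are beyond the scatter.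

Compound 4 `CC[C@H]1CN(c2ncc(-c3nnco3)cc2Cl)CCN1C1CCN(Cc2ccc(Cl)cc2F)CC1` continues this variation: 1,3,4-oxadiazol-2-yl in place of 4H-1,2,4-triazol-3-yl on an aromatic carbon. Going by the values given here, the steps that bear on it are the two that start or end at compound 2, a 7.4-fold lower number from compound 1 to compound 2 (0.87 log units; beyond the scatter) and a 200-fold higher number from compound 2 to compound 3 (2.31 log units; beyond the scatter), together with a 27-fold higher number from compound 1 to compound 3 (1.44 log units; beyond the scatter). They show that a five-membered ring at this position can move the number in either direction by a large margin, and that compound 2 holds the best value seen, so a change away from it is more likely to raise the number than to lower it. The expected step in this assay is therefore an increase, modest rather than large, written as a 4.4-fold higher number from compound 2 to compound 4 (0.64 log units; beyond the scatter). For compound 4 the expected value is 30 nM, within a range of 8 nM to 150 nM.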

Compound 4, half-maximal inhibitory concentration: 1.4 nM
Estimate against measurement, compound 4: 21-fold (1.33 log units) above; the whole stated range lies above it.
By their numbers in this assay, from the lowest: compound 4; then compound 2; then compound 1; then compound 3.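

In this assay, the step of a 4.9-fold lower number from compound 2 to compound 4 (0.69 log units; beyond the scatter) shows that a hydrogen-bond donor on the five-membered ring is not needed for a low number at this position, since 1,3,4-oxadiazol-2-yl has 0 hydrogen-bond donors against 1 in 4H-1,2,4-triazol-3-yl. The step of a 990-fold lower number from compound 3 to compound 4 (2.99 log units; beyond the scatter) links two five-membered aromatic rings on the same aromatic carbon, so ring size alone does not set the number here, and the identity of the ring atoms carries a very wide spread. With the step of a 36-fold lower number from compound 1 to compound 4 (1.56 log units; beyond the scatter), compound 4 joins compound 2 below the nitrile compound 1, while compound 3 goes against any rule that a five-membered ring improves on the nitrile.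

Nothing measured alongside these values bears on why the rings fall in this order. Also open, as far as these compounds go, is where a carboxylic acid, a primary carboxamide or a methyl-substituted 1,3,4-oxadiazol-2-yl at this carbon would fall relative to compound 4, and whether the order of the four compounds would hold in a cell-based read-out.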